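The source may report more compounds than this note shows. Statements on the series, on what has been measured and on what is new or still open speak of the compounds shown alone.

Compound 2 `CC(C)CCc1ccc2c(NCCCNCc3ccco3)ccnc2c1` gives 11200 nM in an ADME assay on HepG2 cells (Homo sapiens) for cytotoxicity, read by luminescence, CellTiter-Glo and ATP content, with a stated time of 72 h (a lower number here means that less compound is needed, a higher number that more compound is needed for the effect), and it stands alongside compound 1 `Fc1ccc(Oc2ccc3c(NCCCNCc4ccco4)ccnc3c2)cc1`, which gives 16000 nM, since the step of a 1.4-fold lower number from compound 1 to compound 2 (0.15 log units; within the scatter) lies within the scatter. Compound 3 `COc1ccccc1Oc1ccc2c(NCCCNCc3ccco3)ccnc2c1` differs from compound 2 by 2-methoxyphenoxy in place of isopentyl on an aromatic carbon. For the measured compounds named here, the only measured step that bears on this change is a 1.4-fold lower number from compound 1 to compound 2 (0.15 log units; within the scatter), which restores an oxygen-linked aromatic ring at the same place on the core and moved the number little. Compound 3 is therefore expected to show no step beyond the scatter, a 1.3-fold higher number from compound 2 to compound 3 (0.10 log units; within the scatter). The estimate for compound 3 is 14000 nM, with a range from 6000 nM to 35000 nM.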

Compound 3, half-maximal effective concentration: 6500 nM
Compound 3: middle estimate off by 2.2-fold (0.33 log units), on the high side, and the stated range covers the measured number.
By their numbers in this assay, from the lowest: compounds 3, 2 and 1 (each within the scatter of the next, the first and the last beyond it).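

In this assay, for the compounds shown here, the aromatic ring on the oxygen alone gives a 2.5-fold lower number from compound 1 to compound 3 (0.39 log units; beyond the scatter), the first step at this position to pass the scatter, with 2-methoxyphenyl in place of 4-fluorophenyl. Replacing isopentyl with 2-methoxyphenoxy gives a 1.7-fold lower number from compound 2 to compound 3 (0.24 log units; within the scatter), so an oxygen-linked aromatic ring does not by itself set compound 3 apart from compound 2. Nothing at hand explains these numbers.

Going by these compounds, whether the step follows the methoxy group or its place on the phenyl ring stays open. So does whether an amine or a carboxylic acid on that ring, or a longer chain in place of isopentyl, would shift the number in this assay beyond the scatter.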